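Allyl in place of hydrogen on the ring oxygen of compound 3

A few compounds are considered here, and "the series" means these few. Any claim that something is new, unique, unknown or untested is made for them only; others in the source may bear on it.

In this study compound 3 `CCOC(=O)c1cnc(-c2ccccc2O)[nH]c1=O` is an ethyl ester that in a functional assay on the whole organism (strain Sprague-Dawley) for inhibition, with Rattus norvegicus as the target, with a stated time of 10 min (on this read-out higher numbers stand for an effect only at larger amounts of compound and lower numbers for an effect already at smaller amounts), gives 5 mg/kg. Of the two compounds in this assay that give a number, compound 3 gives the higher one, while compound 2 `CC(C)Oc1ccccc1-c1ncc(C(=O)O)c(=O)[nH]1` gives 0.8 mg/kg. Compound 1 `O=C(O)c1cnc(-c2ccccc2O)[nH]c1=O` gives only a limit in this assay, > 5 mg/kg, so its number is not known. From the compounds shown here alone, the two measured steps start from compound 1: putting isopropyl in place of hydrogen on an oxygen on an aromatic ring gives an at least 6.2-fold lower number from compound 1 to compound 2 (0.79 log units; beyond the scatter), whereas putting ethyl in place of hydrogen on an oxygen next to a carbonyl group gives a number no higher from compound 1 to compound 3 (the limit leaves the size open), whose size stays open because of the limit of > 5 mg/kg in this assay, at which 1 of the 3 values shown sits.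

Compound 4 `C=CCOc1ccccc1-c1ncc(C(=O)OCC)c(=O)[nH]1` differs from compound 3 in one place: allyl in place of hydrogen on an oxygen on an aromatic ring. Among the compounds with values here, the step that bears on this change is the one from compound 1 to compound 2, which is of the same kind, an alkyl group entering on the same oxygen, and it was at least modest in size and toward lower numbers. The step from compound 1 to compound 3 says only that the ethyl ester itself does not raise the number. A step in this assay of similar direction and size is therefore expected, namely a 5.0-fold lower number from compound 3 to compound 4 (0.70 log units; beyond the scatter). Compound 4 is accordingly estimated at 1 mg/kg in this assay, with a likely range from 0.3 mg/kg to 3 mg/kg.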

Compound 4, dose for 50% inhibition: 0.5 mg/kg
Compound 4: the middle estimate sits 2.0-fold (0.30 log units) above what was measured; the range from low to high includes it.
By their numbers in this assay, from the lowest: compounds 4 and 2 (each within the scatter of the next); then compound 3.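

In this assay, allyl in place of hydrogen on an oxygen on an aromatic ring gives a 10-fold lower number from compound 3 to compound 4 (1.00 log units; beyond the scatter), so a change at this oxygen now has a size read between two numbers, and it is seen on the ethyl ester. The earlier change at this oxygen, with isopropyl, started from compound 1, and its size stayed open: the limit of > 5 mg/kg in this assay, at which 1 of the 4 values shown sits. Both pairs shown in which this oxygen gains a group in place of hydrogen move toward lower numbers, compound 1 to compound 2 with the carboxylic acid and compound 3 to compound 4 with the ethyl ester, and no pair shown goes against this.

From the compounds shown here alone, what a propyl chain, without the double bond, or a benzyl group would give on this oxygen stays open, so the part the double bond of allyl plays in the step cannot be told. Also open, going by these compounds, is how allyl behaves with the carboxylic acid in place of the ethyl ester and how isopropyl behaves with the ethyl ester, which would allow the two groups to be compared on one core.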